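Aryl swap on the thiazole of compound 2

The source may hold more compounds than are shown below. What is called first, only, known or untested is meant among the compounds shown, and "the series" means these compounds.

Among the compounds with values here, compound 2 `Cc1nc(-c2ccsc2)sc1COc1ccc2c(c1)OCC2CC(=O)O` gives 56.5% in a functional assay on CHO cells for agonist activity at Free fatty acid receptor 1 (Homo sapiens), read by FLIPR and calcium flux, tested at 100 nM (a higher number here means a stronger effect of the compound at the concentration tested, a lower number a weaker effect), the higher of the two numbers known so far; compound 1 `O=C(O)CC1COc2cc(OCc3cc(-c4ccccc4)on3)ccc21` gives 0.84% in this assay, a gap beyond the scatter. Compound 3 `Cc1cccc(-c2nc(C)c(COc3ccc4c(c3)OCC4CC(=O)O)s2)c1` carries 3-methylphenyl in place of thiophen-3-yl on an aromatic carbon. Within the data shown here, no measured pair shows this kind of change, so its effect is untested. A step of a number 5.5 percentage points higher from compound 2 to compound 3 (within the scatter) is expected, a small rise that may still sit within the scatter. Compound 3 is estimated at 62%, with a range from 35% to 85%.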

Compound 3, a percentage reported as activity, at one concentration (the size of the read-out at that concentration, not a potency): 47.2%
Compound 3: middle estimate off by 14.8 percentage points, on the high side; the range from low to high includes it.
By their numbers in this assay, from the lowest: compound 1; then compounds 3 and 2 (each within the scatter of the next).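

In this assay, 3-methylphenyl in place of thiophen-3-yl on this aromatic carbon gives a number 9.3 percentage points lower from compound 2 to compound 3 (within the scatter) and so leaves the read-out within the scatter. This position therefore accepts a six-membered aromatic ring of carbon only as well as a five-membered aromatic ring with 1 hetero atom. No measured property bears on this step. Still open, as far as these compounds go, is how a polar substituent such as an amine or a carboxylic acid on the phenyl ring would read, and whether the methyl group of compound 3 contributes at all.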